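From Fluoro to Chloro on the Shared Core

This account rests on a few compounds, and the source may have more. Where it says the series, first, only, none or still open, it means among the compounds named here.

Of the compounds shown here, three on one core have been measured in a functional assay for agonist activity at Alpha-1A adrenergic receptor (Homo sapiens); on this read-out higher numbers stand for larger maximal responses and lower numbers for smaller maximal responses. Compound 1 `CSc1ccc(F)cc1NCC1=NCCN1` gives 90%. Compound 2 `CS(=O)(=O)c1ccc(F)cc1NCC1=NCCN1` gives 96%, and compound 3 `COc1ccc(S(C)(=O)=O)c(NCC2=NCCN2)c1` gives 102%. Compound 1 sits at the low end of these three numbers: its gap to compound 2 lies within the scatter, while its gap to compound 3 lies beyond it. Both measured steps are small: a number 6 percentage points higher from compound 1 to compound 2 (within the scatter) with methylsulfonyl in place of methylsulfanyl on an aromatic carbon, and a number 6 percentage points higher from compound 2 to compound 3 (within the scatter) with methoxy in place of fluoro on an aromatic carbon.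

Compound 4 `CSc1ccc(Cl)cc1NCC1=NCCN1` has not yet been measured in this assay. It differs from compound 1 in one place: chloro in place of fluoro on an aromatic carbon. For the measured compounds named here, of the measured steps, only the one from compound 2 to compound 3 touches the fluoro group, and that step stayed within the scatter; no measured step exchanges one halogen for another. Compound 4 is therefore expected to give a maximal response close to that of compound 1, with no change at the digits printed from compound 1 to compound 4 (within the scatter) expected to stay within the scatter. The estimate for compound 4 is 90%, with a range from 76% to 104%.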

Compound 4, largest response reached (reported as maximum), in percent of the reference or control that the assay uses: 82%
For compound 4 the middle estimate is 8 percentage points above the measured one, within the range that was stated.
By their numbers in this assay, from the lowest: compounds 4, 1, 2 and 3 (each within the scatter of the next, the first and the last beyond it).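

For the compounds shown here, at this position, on an aromatic carbon para to a methylsulfanyl group and meta to a group of 7 heavy atoms, chloro in place of fluoro gives a number 8 percentage points lower from compound 1 to compound 4 (within the scatter) in this assay and so provides the first reading of one halogen exchanged for another on the shared core. Going by these compounds alone, the only earlier step at this position put methoxy in place of fluoro with a methylsulfonyl group at the para carbon, whereas this step keeps the methylsulfanyl group and exchanges one heavy atom for one heavy atom, with no hydrogen-bond donor or acceptor on either side, and the two maximal responses cannot be told apart. Nothing available explains the size of this step or ties it to any property of either halogen.

The compounds shown leave open whether chloro in place of fluoro would read the same with the methylsulfonyl group of compound 2 in the para position. They also leave open how this assay would respond to bromo, an amine, a carboxylic acid or a longer chain such as propoxy at this position.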